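The source may hold more compounds than are shown below. What is called first, only, known or untested is meant among the compounds shown, and "the series" means these compounds.

Compounds measured so far:
- compound 1, `COc1cccc(-c2cc(F)c(NC(=O)/C(C#N)=C(/C)O)cc2OC(C)C)c1`, 981 nM
- compound 2, `CCC(C)Oc1cc(NC(=O)/C(C#N)=C(/C)O)c(F)cc1-c1cccc(C(F)(F)F)c1`, 45.5 nM

In a functional assay on Raji cells (Homo sapiens) for inhibition, read by MTT assay, with a stated time of 96 h (a lower number here means a stronger inhibitor, a higher number a weaker inhibitor), compound 2 gives 45.5 nM, the lower of the two numbers; compound 1 gives 981 nM, a higher number whose gap from compound 2 lies beyond the usual scatter. Compound 3, `CCC(C)Oc1cc(NC(=O)/C(C#N)=C(/C)O)c(F)cc1-c1ccc2ccccc2c1`, has not been measured. It differs from compound 2 in one place: naphthalen-2-yl in place of 3-(trifluoromethyl)phenyl on an aromatic carbon. Among the compounds with values here, no step between two measured compounds shows this change, so the expectation rests on the likeness in count. Compound 3 is expected to sit close to compound 2, with a step of a 1.8-fold higher number from compound 2 to compound 3 (0.25 log units; within the scatter) of modest size, if any, toward a higher number. Compound 3 is estimated at 80 nM, within a range from 25 nM to 300 nM.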

Compound 3, half-maximal inhibitory concentration: 18.8 nM
Estimate against measurement, compound 3: 4.3-fold (0.63 log units) above; the measured number lies below the stated range.
By their numbers in this assay, from the lowest: compound 3; then compound 2; then compound 1.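

In this assay, the change gives a 2.4-fold lower number from compound 2 to compound 3 (0.38 log units; beyond the scatter), a modest step beyond the scatter. At this position, ortho to a sec-butoxy group, two six-membered aromatic rings of carbon only are thus accepted in place of one, with the same count of heavy atoms, and fluorine on this group is not required for a low number. Nothing available here explains the step. As far as these compounds go, whether a plain phenyl, or a naphthalen-2-yl carrying an amine or a carboxylic acid, would keep this number remains open.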